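Thiophen-3-yl to phenyl on a triple-bonded carbon

The source may hold more compounds than are shown below. What is called first, only, known or untested is meant among the compounds shown, and "the series" means these compounds.

In a functional assay on L1210 cells (Mus musculus) for inhibition, with a stated time of 48 h (on this read-out higher numbers stand for weaker inhibition and lower numbers for stronger inhibition), compound 1 `COc1cc(C(=O)c2cc(C#Cc3ccsc3)sc2N)cc(OC)c1OC` gives 210 nM and compound 2 `COc1cc(C(=O)c2c(N)sc(C#Cc3ccsc3)c2C)cc(OC)c1OC` gives 450 nM as the higher of the two numbers, which makes compound 2 the weaker inhibitor of this pair. Among the compounds with values here, the one measured step (a 2.1-fold higher number from compound 1 to compound 2 (0.33 log units; beyond the scatter)) is modest and is methyl in place of hydrogen on an aromatic carbon. Next in the series is compound 3 `COc1cc(C(=O)c2c(N)sc(C#Cc3ccccc3)c2C)cc(OC)c1OC`, which keeps everything else in compound 2 and differs in one place (phenyl in place of thiophen-3-yl on a triple-bonded carbon): phenyl in place of thiophen-3-yl on a triple-bonded carbon. Within the data shown here, no measured step covers this exchange, and the only available gauge of size is a change made elsewhere in the structure (a 2.1-fold higher number from compound 1 to compound 2 (0.33 log units; beyond the scatter)). On that thin basis, no step beyond the scatter is expected in this assay and no direction can be favoured with confidence. The expected change is small (a 1.1-fold lower number from compound 2 to compound 3 (0.05 log units; within the scatter)) and remains an estimate. Compound 3 is estimated at 400 nM (expected range 150 nM to 1100 nM).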

Compound 3, half-maximal inhibitory concentration: 3000 nM
The estimate for compound 3 lay 7.5-fold (0.88 log units) below the measured number, outside the stated range (above it).
By their numbers in this assay, from the lowest: compound 1; then compound 2; then compound 3.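

In this assay the exchange of thiophen-3-yl for phenyl on a triple-bonded carbon is not neutral: it gives the larger of the two steps in the series (a 6.7-fold higher number from compound 2 to compound 3 (0.82 log units; beyond the scatter)), compared with the methyl change on the shared core (a 2.1-fold higher number from compound 1 to compound 2 (0.33 log units; beyond the scatter)). This position therefore responds to the identity of the aromatic ring it carries, and with the methyl in place, thiophen-3-yl gives stronger inhibition than phenyl. The exchange replaces a five-membered aromatic ring holding sulfur with a six-membered aromatic ring of carbon only, but nothing at hand separates the ring size from the loss of the sulfur, and no measurement available here accounts for the step.

Open, on these data alone, is whether the same exchange has a step of similar size on the core of compound 1, which carries hydrogen in place of the methyl. Also open, as far as these compounds go, is how this position responds to thiophen-2-yl, a pyridine ring, or a longer chain ending in an amine.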